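Phenoxy for Phenyl on the Aryl Arm of a Receptor Binder

A few compounds are considered here, and "the series" means these few. Any claim that something is new, unique, unknown or untested is made for them only; others in the source may bear on it.

Three compounds have been measured in an assay on isolated protein for displacement of a labelled ligand from Type-2 angiotensin II receptor (Rattus norvegicus); a lower number here means a stronger inhibitor, a higher number a weaker inhibitor:

Compound 1, `CCCc1cc(Cn2c(CC)nc3c(C)cc(C)nc32)cc(CCC)c1OC(C(=O)O)c1cccc(-c2ccccc2)c1`: 740 nM
Compound 2, `CCCc1cc(Cn2c(CC)nc3c(C)cc(C)nc32)cc(CCC)c1OC(C(=O)O)c1ccc(Cl)cc1`: 450 nM
Compound 3, `CCCc1cc(Cn2c(CC)nc3c(C)cc(C)nc32)cc(CCC)c1OC(C(=O)O)c1ccc(C)cc1`: 400 nM

Compound 1 stands at the highest of the three numbers, but neither of its companions is separated from it beyond the scatter: a 1.6-fold lower number from compound 1 to compound 2 (0.22 log units; within the scatter) and a 1.9-fold lower number from compound 1 to compound 3 (0.27 log units; within the scatter). The two smaller compounds sit equally close to each other, with a 1.1-fold lower number from compound 2 to compound 3 (0.05 log units; within the scatter). All three differ only in the group carried on the aromatic ring attached to the saturated chain carbon bound to a carbonyl carbon and an oxygen on an aromatic ring, and none of these swaps moved the number beyond the scatter.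

Compound 4, `CCCc1cc(Cn2c(CC)nc3c(C)cc(C)nc32)cc(CCC)c1OC(C(=O)O)c1cccc(Oc2ccccc2)c1`, arises from compound 1 by phenoxy in place of phenyl on an aromatic carbon. Among the compounds with values here, no measured step inserts an oxygen in this way, so the three flat steps on the same ring are the only guide. On that basis, the step of a 1.2-fold lower number from compound 1 to compound 4 (0.09 log units; within the scatter) is expected to stay within the scatter. Compound 4 is therefore estimated at 600 nM in this assay, with a likely range of 250 nM to 1500 nM.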

Compound 4, half-maximal inhibitory concentration: 1600 nM
Estimate against measurement, compound 4: 2.7-fold (0.43 log units) below; the measured number lies above the stated range.
By their numbers in this assay, from the lowest: compounds 3, 2 and 1 (each within the scatter of the next); then compound 4.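

Within the data shown here, the swap of phenyl for phenoxy on this aromatic ring is the first single change here to move the number in this assay beyond the scatter: a 2.2-fold higher number from compound 1 to compound 4 (0.33 log units; beyond the scatter). The step is modest, but it shows that the number does respond to a change at this place, whereas the earlier swaps on the same ring left it within the scatter. Nothing shown here accounts for the rise that comes with the added oxygen and its hydrogen-bond acceptor.

Going by these compounds, it remains open whether the oxygen itself matters or only the extra atom linking the two rings. A benzyl group, with a carbon where compound 4 has its oxygen, and an anilino group, with a nitrogen there, would help to separate these two readings.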